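The source may report more compounds than this note shows. Statements on the series, on what has been measured and on what is new or still open speak of the compounds shown alone.

Measured in a functional assay on HL-60 cells (Homo sapiens) for inhibition, read by CCK-8 assay, with a stated time of 48 h, tested at 20 uM; on this read-out higher numbers stand for more inhibition of growth at the one concentration tested and lower numbers for less inhibition of growth:
compound 1 `COc1ccc(S(=O)(=O)Oc2ccccc2/C=C(\C#N)C(=O)Nc2nnc(-c3cccs3)s2)cc1`: 67%
compound 2 `COc1ccc(Cc2nnc(NC(=O)/C(C#N)=C/c3ccccc3OS(=O)(=O)c3ccccc3[N+](=O)[O-])s2)cc1`: 25%
compound 3 `COc1ccc(S(=O)(=O)Oc2ccccc2/C=C(\C#N)C(=O)Nc2nnc(Cc3cccc4ccccc34)s2)cc1`: 98%

Compound 3, at 98%, holds the highest of the three numbers, beyond the scatter from both other compounds. Compound 4 `N#C/C(=C\c1ccccc1OS(=O)(=O)c1ccccc1[N+](=O)[O-])C(=O)Nc1nnc(Cc2cccc3ccccc23)s1` departs from it in one place: 2-nitrophenyl in place of 4-methoxyphenyl on a sulfonyl sulfur. This puts 2-nitrophenyl in place of 4-methoxyphenyl on a sulfonyl sulfur.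

Within the data shown here, no measured step isolates this change. Among the measured compounds shown here, the only single-place step, a number 31 percentage points higher from compound 1 to compound 3 (beyond the scatter), concerns a different group, on an aromatic carbon, and shows only that one change can move this series far. Compound 2 carries the same 2-nitrophenyl and gives 25%, but it also differs from compound 3 in a second place. The data do not separate these two differences.

A fall beyond the scatter is therefore expected in this assay, though one smaller than the full gap between those two values. The expected move is a number 36 percentage points lower from compound 3 to compound 4 (beyond the scatter). For compound 4 the estimate is 62%, with an expected range of 32% to 90%.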

Compound 4, percent growth inhibition at one concentration: 23%
Compound 4: the middle estimate sits 39 percentage points above what was measured; measured number outside the range, below it.
By their numbers in this assay, from the lowest: compounds 4 and 2 (each within the scatter of the next); then compound 1; then compound 3.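

In this assay, the change on the sulfonyl sulfur now stands as a single-place step: 2-nitrophenyl in place of 4-methoxyphenyl gives a number 75 percentage points lower from compound 3 to compound 4 (beyond the scatter). With 2-nitrophenyl held on that sulfur, naphthalen-1-yl in place of 4-methoxyphenyl on the saturated chain carbon gives a number 2 percentage points lower from compound 2 to compound 4 (within the scatter), so the group at that carbon makes no readable difference in this pair. No measurement at hand bears on the reason for the large sulfonyl step.

Among these compounds, open is how an unsubstituted phenyl or a methyl group on the sulfonyl sulfur would read, since only two groups there can be compared. Also open, on these data alone, is whether a 4-methoxyphenyl on the saturated chain carbon would read the same as naphthalen-1-yl with 4-methoxyphenyl on the sulfonyl sulfur.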